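Trading trifluoromethyl for dimethylcarbamoyl on the oxazole core

The source may hold more compounds than are shown below. What is called first, only, known or untested is meant among the compounds shown, and "the series" means these compounds.

Measured so far:
compound 1 `O=C(CCc1ccc(Oc2ccccc2)cc1)c1ncc(C(F)(F)F)o1`: 2 nM
compound 2 `O=C(CCc1ccc(COc2ccccc2)cc1)c1ncc(-c2cccc(-c3nnn[nH]3)n2)o1`: 21 nM
compound 3 `COC(=O)c1cnc(C(=O)CCc2ccc(-c3ccccc3)cc2)o1`: 1.5 nM

In an assay for inhibition of Fatty-acid amide hydrolase 1 (Rattus norvegicus) (on this read-out higher numbers stand for weaker inhibition and lower numbers for stronger inhibition), compound 1 gives 2 nM, the second highest of the three numbers. Compound 3 sits within the scatter of compound 1, so no order between them can be claimed; compound 2, with its far higher number, lies beyond the scatter and is the weaker of the three. Compound 4 `CN(C)C(=O)c1cnc(C(=O)CCc2ccc(Oc3ccccc3)cc2)o1` differs from compound 1 in one place: dimethylcarbamoyl in place of trifluoromethyl on an aromatic carbon. Among the compounds with values here, no measured pair shows this exact change, and compound 3, which carries a different group at that position, gives a number close to compound 1. A modest step toward weaker inhibition is therefore expected in this assay, about a 2.5-fold higher number from compound 1 to compound 4 (0.40 log units; beyond the scatter), close to the edge of the scatter. Compound 4 is expected to give roughly 5 nM, within 1.5 nM to 20 nM.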

Compound 4, inhibition constant: 5.4 nM
For compound 4 the middle estimate is 1.1-fold (0.03 log units) below the measured one, within the range that was stated.
By their numbers in this assay, from the lowest: compounds 3 and 1 (each within the scatter of the next); then compound 4; then compound 2.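

In this assay, within the data shown here, the step on the aromatic carbon next to the ring oxygen, dimethylcarbamoyl in place of trifluoromethyl, gives a 2.7-fold higher number from compound 1 to compound 4 (0.43 log units; beyond the scatter) and is the first single-place change read at this position. The larger group, with its hydrogen-bond acceptor, costs only modest inhibition, and compound 4 still gives 5.4 nM in this assay. Nothing shown gives a reason for this step. Going by these compounds, whether the carbonyl or the two methyl groups carry the shift stays open. So does the outcome for a carboxylic acid, a primary amide or a nitrile on the core of compound 1.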